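Swapping an amide for a sulfonamide on the shared core

The compounds below may be only part of what the source reports. "The series", "measured", "known", "first", "only" and "open" are said of these compounds alone.

Measured so far:
Compound 1 `O=S(=O)(NCCCNc1nccc(-c2c(-c3cccc(F)c3)nc3sccn23)n1)c1cccc(F)c1` gives 8550 nM in a functional assay on SK-MEL-28 cells (Homo sapiens) for cytotoxicity, read by MTT assay; a lower number here means a stronger inhibitor, a higher number a weaker inhibitor.
Compound 2 `O=C(NCCNc1nccc(-c2c(-c3cccc(F)c3)nc3sccn23)n1)c1c(F)cccc1F` gives 11400 nM in this assay.

Going by the values given here, compound 2 has the highest of the two numbers, but its only neighbour, compound 1, sits within the scatter: a 1.3-fold higher number from compound 1 to compound 2 (0.12 log units; within the scatter). Compound 3 `O=S(=O)(NCCNc1nccc(-c2c(-c3cccc(F)c3)nc3sccn23)n1)c1ccc(F)cc1` differs from compound 2 by (4-fluorophenyl)sulfonyl in place of (2,6-difluorophenyl)carbonyl on an amine nitrogen. Among the compounds with values here, the one measured step bears on this only in part, since it also shortened the chain, and it was small. A sulfonyl returns here, so in this assay compound 3 is expected to show a 1.3-fold lower number from compound 2 to compound 3 (0.10 log units; within the scatter), landing near 9000 nM within 3000 nM to 27000 nM.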

Compound 3, half-maximal inhibitory concentration: 9450 nM
The estimate for compound 3 lay 1.1-fold (0.02 log units) below the measured number; low and high end bracket the measured number.
By their numbers in this assay, from the lowest: compounds 1, 3 and 2 (each within the scatter of the next).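

With the chain held fixed, (4-fluorophenyl)sulfonyl on the amine nitrogen in place of (2,6-difluorophenyl)carbonyl gives only a small step in this assay, a 1.2-fold lower number from compound 2 to compound 3 (0.08 log units; within the scatter), although the fluorine pattern changes along with the linking group. Comparing the two sulfonyl compounds, ((4-fluorophenyl)sulfonyl)amino in place of (((3-fluorophenyl)sulfonyl)amino)methyl also gives a small step, a 1.1-fold higher number from compound 1 to compound 3 (0.04 log units; within the scatter). No measurement here explains why these steps are small. All three compounds end in a fluorinated phenyl ring. On these data alone, whether an amine or a carboxylic acid in place of that ring, or a longer chain, would move the number beyond the scatter remains open.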